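Propylamino in Place of Propoxy: What to Expect of Compound 3

The source may report more compounds than this note shows. Statements on the series, on what has been measured and on what is new or still open speak of the compounds shown alone.

Among the measured compounds shown here, compound 2 `CCCOc1nc(N)c2nc(O)n(Cc3ccccc3)c2n1` gives 0.01 uM in a functional assay (spleen, spleen) for activation, with Mus musculus as the target (on this read-out lower numbers stand for an effect already at smaller amounts and higher numbers for an effect only at larger amounts of compound), the lowest of the two numbers measured so far; its nearest neighbour, compound 1 `Nc1nc(O)nc2c1nc(O)n2Cc1ccccc1`, gives 0.1 uM. For the measured compounds named here, the one measured step, a 10-fold lower number from compound 1 to compound 2 (1.00 log units; beyond the scatter), concerns the propyl chain itself, not the atom that carries it. Compound 3 `CCCNc1nc(N)c2nc(O)n(Cc3ccccc3)c2n1` differs from compound 2 by propylamino in place of propoxy on an aromatic carbon. Going by the values given here, no measured step bears directly on this exchange, so only a small move toward a higher number, if any, is expected, a 2.0-fold higher number from compound 2 to compound 3 (0.30 log units; within the scatter). Compound 3 is estimated at 0.02 uM, within 0.005 uM to 0.08 uM.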

Compound 3, minimum effective concentration: 0.1 uM
Compound 3: middle estimate off by 5.0-fold (0.70 log units), on the low side; the measured number lies above the stated range.
By their numbers in this assay, from the lowest: compound 2; then compounds 1 and 3 (each within the scatter of the next).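

In this assay, the atom carrying the propyl chain proves to matter at this position: propylamino in place of propoxy gives a 10-fold higher number from compound 2 to compound 3 (1.00 log units; beyond the scatter) and so loses the gain seen with propoxy. Measured against the hydroxy group, propylamino gives no change at the digits printed from compound 1 to compound 3 (within the scatter), so the propyl chain brings a gain here only when carried on oxygen. No evidence at hand accounts for this difference between oxygen and nitrogen. Open, from the compounds shown here alone, is how butoxy or a shorter methoxy would compare with propoxy, and whether butylamino or dimethylamino would behave like propylamino.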